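Trading a cyclopentyl for an isopropyl on the chalcone side chain

The source may report more compounds than this note shows. Statements on the series, on what has been measured and on what is new or still open speak of the compounds shown alone.

In a functional assay on PC-3 cells (Homo sapiens) for antiproliferative activity, read by sulforhodamine B assay (on this read-out lower numbers stand for stronger inhibition of growth and higher numbers for weaker inhibition of growth), compound 2 `O=C(/C=C/c1ccc(O)cc1)c1c(O)cccc1OCCC1CCCC1` gives 3480 nM, the only numerical result in this set. Compound 1 `COc1cccc(OCCC(C)(C)C)c1C(=O)/C=C/c1ccc(O)cc1` reaches only a limit of the assay, > 30000 nM, as noted in the limit of > 30000 nM in this assay, at which 1 of the 2 values shown sits. Compound 3 `CC(C)CCOc1cccc(O)c1C(=O)/C=C/c1ccc(O)cc1` differs from compound 2 by isopropyl in place of cyclopentyl on a saturated chain carbon, two bonds along the chain from an oxygen on an aromatic ring. Among the measured compounds shown here, no measured step of this kind is available, so the expected change from compound 2 to compound 3 is a 1.4-fold higher number from compound 2 to compound 3 (0.16 log units; within the scatter), which is judged to lie within the usual scatter, with no clear direction. Compound 3 is therefore estimated at 5000 nM, with a range from 2000 nM to 15000 nM.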

Compound 3, concentration for 50% growth inhibition: 11500 nM
Compound 3: the middle estimate sits 2.3-fold (0.36 log units) below what was measured, within the range that was stated.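

In this assay this position proves sensitive to the shape of the side chain: isopropyl in place of cyclopentyl on a saturated chain carbon, two bonds along the chain from an oxygen on an aromatic ring, gives a 3.3-fold higher number from compound 2 to compound 3 (0.52 log units; beyond the scatter) on this read-out. Among the compounds shown here, it is the first step at this position that can be read, and compound 3 keeps a measurable number with the smaller, ring-free group. Nothing measured here accounts for the step. On these data alone, whether a cyclohexyl ring, a longer chain or an amine at this place would move the number further stays open.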